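Thiophene for phenyl on the acyl carbonyl of the nitro series

This account rests on a few compounds, and the source may have more. Where it says the series, first, only, none or still open, it means among the compounds named here.

Three thiourea compounds share a core and have been measured in a functional assay on HeLa cells (Homo sapiens) for cytotoxicity, read by MTT assay, with a stated time of 24 h; a lower number here means a stronger inhibitor, a higher number a weaker inhibitor. Compound 1 `O=C(NC(=S)Nc1nc2cc([N+](=O)[O-])ccc2s1)N1CCOCC1` gives 54800 nM, compound 2 `Nc1ccc2sc(NC(=S)NC(=O)c3cccs3)nc2c1` gives 56100 nM, and compound 3 `O=C(NC(=S)Nc1nc2cc([N+](=O)[O-])ccc2s1)c1ccccc1` gives 75100 nM; all three numbers lie within the scatter of one another. Within the data shown here, the one single-point step among them, a 1.4-fold higher number from compound 1 to compound 3 (0.14 log units; within the scatter), did not move the number beyond the scatter. Compound 4 `O=C(NC(=S)Nc1nc2cc([N+](=O)[O-])ccc2s1)c1cccs1` differs from compound 3 by thiophen-2-yl in place of phenyl on a carbonyl carbon. Compound 2 also carries the thiophene carbonyl, and its value and that of compound 3 sit close together. No step beyond the scatter is therefore expected; the step is estimated at a 1.1-fold lower number from compound 3 to compound 4 (0.03 log units; within the scatter). Compound 4 is expected to give about 70000 nM, in a range from 35000 nM to 140000 nM.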

Compound 4, half-maximal inhibitory concentration: 72600 nM
The estimate for compound 4 lay 1.0-fold (0.02 log units) below the measured number; low and high end bracket the measured number.
By their numbers in this assay, from the lowest: compounds 1, 2, 4 and 3 (each within the scatter of the next).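

In this assay, thiophen-2-yl in place of phenyl on a carbonyl carbon gives a 1.0-fold lower number from compound 3 to compound 4 (0.01 log units; within the scatter) and thiophen-2-yl in place of morpholin-4-yl gives a 1.3-fold higher number from compound 1 to compound 4 (0.12 log units; within the scatter) in the nitro series, so all three groups now read alike at this place. With the thiophene carbonyl held fixed, nitro in place of amino on an aromatic carbon gives a 1.3-fold higher number from compound 2 to compound 4 (0.11 log units; within the scatter) and likewise stays within the scatter. No data at hand account for these small steps.

Going by these compounds, whether a carboxylic acid, an amine or a longer chain on the carbonyl carbon would move the number beyond the scatter remains open.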